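Half-life on rabbit aorta: methyl to isopropyl on the oxygen

This account rests on a few compounds, and the source may have more. Where it says the series, first, only, none or still open, it means among the compounds named here.

Of the compounds shown here, two with a shared core have been measured in a functional assay on aorta with Voltage-dependent L-type calcium channel subunit alpha-1C (Oryctolagus cuniculus) as the target; on this read-out higher numbers stand for a longer-lived compound and lower numbers for a shorter-lived compound. Compound 1 `CC1=NC(C)=C(C(=O)OCCCN2C(=O)c3ccccc3S2(=O)=O)C(c2cccc([N+](=O)[O-])c2)/C1=C(\O)OC(C)C` gives 0.0783 h in this assay. Compound 2 `CO/C(O)=C1\C(C)=NC(C)=C(C(=O)OCCCN2C(=O)c3ccccc3S2(=O)=O)C1c1ccccc1[N+](=O)[O-]` gives 0.0817 h in this assay. Compound 2 holds the larger of the two values, but the gap to compound 1 lies within the scatter of repeated measurements, so the two compounds cannot be told apart on these numbers.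

Compound 3 `CC1=NC(C)=C(C(=O)OCCCN2C(=O)c3ccccc3S2(=O)=O)C(c2ccccc2[N+](=O)[O-])/C1=C(\O)OC(C)C` has not yet been measured. It differs from compound 2 in one place: isopropyl in place of methyl on an oxygen on an unsaturated carbon. Put another way, the methoxy becomes an isopropoxy. Among the compounds with values here, no measured pair shows this exact change on its own, so the direction of any effect is unknown. Both measured values sit close together, and a change of this size, at a position away from the rest of the molecule, is not expected to move the value beyond the scatter in either direction. The expected step from compound 2 to compound 3 in this assay is therefore a 1.0-fold lower number from compound 2 to compound 3 (0.01 log units; within the scatter). Compound 3 is estimated to give 0.08 h in this assay, within a range from 0.04 h to 0.16 h.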

Compound 3, half-life: 0.145 h
The estimate for compound 3 lay 1.8-fold (0.26 log units) below the measured number, within the range that was stated.
By their numbers in this assay, from the lowest: compounds 1, 2 and 3 (each within the scatter of the next).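

In this assay, within the data shown here, compound 2 and compound 3 form the first pair that isolates isopropyl in place of methyl on this oxygen, and the result, a 1.8-fold higher number from compound 2 to compound 3 (0.25 log units; within the scatter), shows that this swap gives no step that can be told from the scatter. Compound 1 and compound 3 form a second such pair, isolating 2-nitrophenyl in place of 3-nitrophenyl on a saturated ring carbon, and a 1.9-fold higher number from compound 1 to compound 3 (0.27 log units; within the scatter) is likewise no readable step, something the earlier pair, which differs in two places, could not show. Nothing available here bears on what lies behind these small steps.

Still open, on these data alone, is whether a longer chain, such as n-butyl, or a chain ending in an amine, on this oxygen would give a step beyond the scatter in this assay. Equally open, as far as these compounds go, is whether a phenyl carrying a nitrile in place of the nitro group, on the same saturated ring carbon, would leave the half-life just as unmoved.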